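This account rests on a few compounds, and the source may have more. Where it says the series, first, only, none or still open, it means among the compounds named here.

Measured compounds:
Compound 1, `CC1(C)c2[nH]nc(NC(=O)c3ccccc3)c2CN1Cc1ccccc1`, gives 1240 nM in an assay on Sf21 cells for inhibition of high affinity nerve growth factor receptor (Homo sapiens), read by HTRF, with a stated time of 30 min, in the presence of a further agent that is not named here; on this read-out lower numbers stand for stronger inhibition and higher numbers for weaker inhibition.
Compound 2, `CC1(C)c2[nH]nc(NC(=O)c3ccccc3)c2CN1Cc1cccc(I)c1`, gives 1360 nM in this assay.

Compound 1 has the lowest of the two numbers, with compound 2 nearest to it: the step is a 1.1-fold higher number from compound 1 to compound 2 (0.04 log units; within the scatter), so the two values cannot be told apart. The compound not yet measured is compound 3, `CC1(C)c2[nH]nc(NC(=O)c3ccccc3)c2CN1Cc1ccc(F)cc1`. Compared with compound 1 it differs by fluoro in place of hydrogen on an aromatic carbon.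

Within the data shown here, only one measured step bears on this change. The step from compound 1 to compound 2 likewise exchanges a ring hydrogen for a halogen, there iodo, and it came out at a 1.1-fold higher number from compound 1 to compound 2 (0.04 log units; within the scatter), within the scatter. Fluoro is the smaller halogen in terms of what is counted, but the one kindred step gives no sign that a halogen at this kind of position moves the number. The expectation for the step to compound 3 in this assay is therefore no change beyond the scatter, in either direction.

Compound 3 is expected to give about 1200 nM, within a range of 600 nM to 2400 nM, which corresponds to an estimated step of a 1.0-fold lower number from compound 1 to compound 3 (0.01 log units; within the scatter).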

Compound 3, half-maximal inhibitory concentration: 1180 nM
Compound 3: the middle estimate sits 1.0-fold (0.01 log units) above what was measured; the measured number falls inside the stated range.
By their numbers in this assay, from the lowest: compounds 3, 1 and 2 (each within the scatter of the next).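

In this assay, fluoro on the aromatic carbon para to a large group, which turns benzyl into 4-fluorobenzyl, gives a 1.1-fold lower number from compound 1 to compound 3 (0.02 log units; within the scatter), so a second halogen, at a different place on the ring from the iodo of compound 2, also gives a number that cannot be told apart from that of compound 1. Exchanging 3-iodophenyl for 4-fluorophenyl gives a 1.2-fold lower number from compound 2 to compound 3 (0.06 log units; within the scatter), so the two halogen-bearing compounds cannot be told apart either, although they differ in both the halogen and its place. Among these three compounds, hydrogen, fluoro and iodo on this ring all give values within the scatter of one another, and nothing measured here gives a reason for that.

On these data alone, it remains open whether an amine, a carboxylic acid or a methoxy group on this ring would give a step beyond the scatter, and whether fluoro and iodo would behave alike if their places were exchanged. The compounds shown also leave open what a chloro or amino group on the benzoyl ring of the amide would do, since all three share that part unchanged.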